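The source may hold more compounds than are shown below. What is called first, only, known or untested is meant among the compounds shown, and "the series" means these compounds.

The study covers four closely related compounds on a shared core. Compound 1 `CCCC1CCC(OC(=O)N[C@@H](CC(C)C)C(=O)N[C@H](C=O)C[C@@H]2CCNC2=O)CC1` carries a propyl group on a saturated ring carbon together with a formyl group; compound 2 `CC(C)C[C@H](NC(=O)OC1CCCCC1)C(=O)N[C@H](C=O)C[C@@H]1CCNC1=O` lacks the propyl; compound 3 `CCCC1CCC(OC(=O)N[C@@H](CC(C)C)C(=O)N[C@@H](C[C@@H]2CCNC2=O)C(O)S(=O)(=O)O)CC1` keeps the propyl but bears hydroxy(sulfo)methyl in place of the formyl. In a toxicity assay on L929 cells (Mus musculus) for cytotoxicity (on this read-out lower numbers stand for higher toxicity in this test and higher numbers for lower toxicity in this test), compound 1 reaches only a limit of > 100000 nM. In this assay compound 2 likewise sits at a limit of > 100000 nM. For compound 3 this assay again gives only a limit, > 100000 nM. Compound 3 thus stands where every value shown stands, at the limit of > 100000 nM in this assay, at which 3 of the 3 values shown sit.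

The step to compound 4 `CC(C)C[C@H](NC(=O)OC1CCCCC1)C(=O)N[C@@H](C[C@@H]1CCNC1=O)C(O)S(=O)(=O)O` is hydrogen in place of propyl on a saturated ring carbon. Going by the values given here, two measured steps bear on it: the same change made on the formyl compounds, a step that the two limits leave unreadable from compound 1 to compound 2, and the change that leads into compound 3, a step that the two limits leave unreadable from compound 1 to compound 3. Both run between two limits, so their sizes cannot be read and no direction can be taken from them. Among the compounds with values here, the expectation for compound 4 is therefore no step in this assay beyond the scatter, a number no higher from compound 3 to compound 4 (the limit leaves the size open), and compound 4 is expected to be reported again most likely only as a limit. Compound 4 is estimated at 100000 nM, within 50000 nM to 300000 nM.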

Compound 4, half-maximal cytotoxic concentration: > 100000 nM
Compound 4 ended at the assay's limit (the forecaster's own chance of this, stated with the estimate: 85%); the middle value lies on the limit itself.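

Compound 4 also gives only a limit in this assay, so neither the step from compound 3 to compound 4 nor the step from compound 2 to compound 4 can be read: the limit of > 100000 nM in this assay, at which 4 of the 4 values shown sit. The compounds shown leave open whether swapping propyl for hydrogen, or formyl for hydroxy(sulfo)methyl, changes the read-out at all.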